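Ethyl for pyridin-3-yl: from compound 3 to compound 4

This account rests on a few compounds, and the source may have more. Where it says the series, first, only, none or still open, it means among the compounds named here.

Compound 1 `COc1ccc(-c2cnc(NC(=O)C3CCNCC3)n2C)cc1`: > 100000 nM, a limit
Compound 2 `CCCC(=O)Nc1ncc(-c2ccc(OC)cc2)n1C`: > 100000 nM, a limit
Compound 3 `COc1ccc(-c2cnc(NC(=O)c3cccnc3)n2C)cc1`: > 100000 nM, a limit

In a toxicity assay on THP-1 cells (Homo sapiens) for inhibition (on this read-out higher numbers stand for lower toxicity in this test and lower numbers for higher toxicity in this test), compound 3 stands at > 100000 nM, which is a limit and not a number. The whole series shares this reading: the limit of > 100000 nM in this assay, at which 3 of the 3 values shown sit.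

Compound 4 `CCC(=O)Nc1ncc(-c2ccc(OC)cc2)n1C` differs from compound 3 by one change: ethyl in place of pyridin-3-yl on a carbonyl carbon. The steps measured at that carbonyl carbon are a step that the two limits leave unreadable from compound 1 to compound 2, a step that the two limits leave unreadable from compound 1 to compound 3 and a step that the two limits leave unreadable from compound 2 to compound 3. None of them has a readable size, so no direction can be drawn from them, and no step beyond the scatter is expected in this assay. The step expected is a number no higher from compound 3 to compound 4 (the limit leaves the size open). For compound 4 the estimated value is 100000 nM, with an expected range from 60000 nM to 150000 nM.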

Compound 4, half-maximal cytotoxic concentration: > 100000 nM
Compound 4: only a limit was reported; the forecaster's own chance of this, stated with the estimate: 90%; the middle value sits exactly at the limit.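

Compound 4 gives no readable step against compound 1, compound 2 or compound 3, since all four values are limits in this assay: the limit of > 100000 nM in this assay, at which 4 of the 4 values shown sit.

As far as these compounds go, whether these four compounds differ at all in this assay, and which group on the carbonyl carbon would give a number instead of a limit, stays open.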